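From fluoro to iodo: a stability estimate

The source may report more compounds than this note shows. Statements on the series, on what has been measured and on what is new or still open speak of the compounds shown alone.

Values in an ADME assay on microsomes from liver (Homo sapiens) for metabolic stability, read by LC-MS, using NADPH, with a stated time of 30 min, tested at 1 uM (on this read-out lower numbers stand for a less stable compound and higher numbers for a more stable compound), for three compounds
Compound 1 `C=CC(=O)Nc1cc(Nc2ncc(I)c(Nc3ccccc3S(=O)(=O)N(C)C)n2)c(OC)cc1N(C)CCN(C)C` gives 13%
Compound 2 `C=CC(=O)Nc1cc(Nc2ncc(Cl)c(Nc3ccccc3S(=O)(=O)C(C)C)n2)c(OC)cc1N(C)CCN(C)C` gives 16%
Compound 3 `C=CC(=O)Nc1cc(Nc2ncc(F)c(Nc3ccccc3S(=O)(=O)C(C)C)n2)c(OC)cc1N(C)CCN(C)C` gives 26%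

Compound 3 (at 26%) lies within the scatter of compound 2 and beyond the scatter from compound 1, which has the lower number. Compound 4 `C=CC(=O)Nc1cc(Nc2ncc(I)c(Nc3ccccc3S(=O)(=O)C(C)C)n2)c(OC)cc1N(C)CCN(C)C` has iodo in place of fluoro on an aromatic carbon, ortho to a large group and para to a large group (in counts, (iodo in place of fluoro on an aromatic carbon)). Within the data shown here, the one measured step at this place is a number 10 percentage points higher from compound 2 to compound 3 (within the scatter) for fluoro in place of chloro, so it runs the opposite way and involves no iodo. Compound 1 (at 13%) does carry iodo, but it also differs elsewhere. A fall of similar size is therefore expected in this assay (estimated as a number 11 percentage points lower from compound 3 to compound 4 (beyond the scatter)). Compound 4 is estimated at 15% (expected range 7% to 25%) in this measurement.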

Compound 4, percent of the compound remaining: 14%
The estimate for compound 4 lay 1 percentage points above the measured number, within the range that was stated.
By their numbers in this assay, from the lowest: compounds 1, 4, 2 and 3 (each within the scatter of the next, the first and the last beyond it).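

In this assay, among these compounds, iodo in place of fluoro on the aromatic carbon gives a number 12 percentage points lower from compound 3 to compound 4 (beyond the scatter) and so is the first step at this place to pass the scatter, while iodo in place of chloro gives a number 2 percentage points lower from compound 2 to compound 4 (within the scatter) and separates nothing. With iodo held fixed, isopropyl in place of dimethylamino on the sulfonyl sulfur gives a number 1 percentage points higher from compound 1 to compound 4 (within the scatter) and likewise separates nothing. Nothing available explains these steps. From the compounds shown here alone, how a nitrile or a methyl would behave at this place remains open. So does the effect of a morpholine on the sulfonyl sulfur.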